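Trifluoromethoxy for Chloro on the Anilide of Compound 3

The compounds below may be only part of what the source reports. "The series", "measured", "known", "first", "only" and "open" are said of these compounds alone.

Three compounds share one core and differ only in the aryl group on the amide nitrogen. Compound 1 `Cc1cc(C(=O)Nc2ccc(F)cc2)nn1-c1cccc(C(F)(F)F)c1` carries a 4-fluorophenyl there and in an assay on HEK293 cells for binding affinity to Neuropeptide Y receptor type 5 (Homo sapiens), read by radioligand binding (a higher number here means a weaker inhibitor, a lower number a stronger inhibitor), compound 1 gives 800 nM. Compound 2 `Cc1ccccc1NC(=O)c1cc(C)n(-c2cccc(C(F)(F)F)c2)n1` carries a 2-methylphenyl, and in this assay compound 2 gives 573 nM. Compound 3 `Cc1cc(C(=O)Nc2cccc(Cl)c2)nn1-c1cccc(C(F)(F)F)c1` carries a 3-chlorophenyl, and in this assay compound 3 gives 520 nM, the lowest of the three numbers, though the steps of a 1.5-fold lower number from compound 1 to compound 3 (0.19 log units; within the scatter) and a 1.1-fold lower number from compound 2 to compound 3 (0.04 log units; within the scatter) both stay within the scatter, as does a 1.4-fold lower number from compound 1 to compound 2 (0.14 log units; within the scatter), so no order among the three can be read from these values.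

Compound 4 `Cc1cc(C(=O)Nc2cccc(OC(F)(F)F)c2)nn1-c1cccc(C(F)(F)F)c1` differs from compound 3 only in that part: trifluoromethoxy in place of chloro on an aromatic carbon. All three measured steps bear on this change, since each exchanges one substituent on the same aryl group for another, and none of them moved this assay beyond the scatter. On that evidence a further exchange of the same kind is expected to leave the number close to that of compound 3, in no particular direction. Compound 4 is therefore estimated at 500 nM in this assay, with a likely range from 200 nM to 1500 nM, which corresponds to the expected step of a 1.0-fold lower number from compound 3 to compound 4 (0.02 log units; within the scatter).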

Compound 4, half-maximal inhibitory concentration: 431 nM
Estimate against measurement, compound 4: 1.2-fold (0.06 log units) above, within the range that was stated.
By their numbers in this assay, from the lowest: compounds 4, 3, 2 and 1 (each within the scatter of the next).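

Replacing chloro with trifluoromethoxy on the same aromatic carbon gives a 1.2-fold lower number from compound 3 to compound 4 (0.08 log units; within the scatter) in this assay, even though the entering group has five heavy atoms where the leaving group has one and adds a hydrogen-bond acceptor that chloro lacks. The earlier steps shown here exchanged aryl groups whose substituents differed in both identity and place, whereas this pair holds the place fixed and changes only the substituent, showing that this particular difference in size and acceptor count does not move the number beyond the scatter. The data shown offer no measured property that would explain this outcome.

The compounds shown leave open whether any substituent at this position can move the number beyond the scatter, for instance an amine or a carboxylic acid, whose effect on the aromatic carbon cannot be judged from chloro and trifluoromethoxy alone. They also leave open how the number responds to changes away from the anilide, such as a longer chain in place of the methyl on the shared core or a different group in place of the trifluoromethyl on the other aryl ring.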